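Chloro to bromo on the triazole aryl ring

The source may hold more compounds than are shown below. What is called first, only, known or untested is meant among the compounds shown, and "the series" means these compounds.

Measured so far in a functional assay on A549 cells (Homo sapiens) for antiproliferative activity, read by MTT assay, with a stated time of 48 h; a lower number here means a stronger inhibitor, a higher number a weaker inhibitor:
compound 1, `Cc1ccccc1-n1nncc1CN1C(=O)C2(C(C#N)=C(N)Oc3c2c2nc4ccccc4nc2c2ccccc32)c2ccccc21`: > 50000 nM, a limit of the assay
compound 2, `N#CC1=C(N)Oc2c(c3nc4ccccc4nc3c3ccccc23)C12C(=O)N(Cc1cnnn1-c1ccc(F)cc1)c1ccccc12`: > 50000 nM, a limit of the assay
compound 3, `N#CC1=C(N)Oc2c(c3nc4ccccc4nc3c3ccccc23)C12C(=O)N(Cc1cnnn1-c1cccc(Cl)c1)c1ccccc12`: 32600 nM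

Within the data shown here, compound 3 holds the only number in the set; the other two entries sit at the limit of > 50000 nM in this assay, at which 2 of the 3 values shown sit. The measured steps of an at least 1.5-fold lower number from compound 1 to compound 3 (0.18 log units; that floor lies within the scatter) and an at least 1.5-fold lower number from compound 2 to compound 3 (0.18 log units; that floor lies within the scatter) read only as floors, and a step that the two limits leave unreadable from compound 1 to compound 2 cannot be read at all. Compound 4, `N#CC1=C(N)Oc2c(c3nc4ccccc4nc3c3ccccc23)C12C(=O)N(Cc1cnnn1-c1cccc(Br)c1)c1ccccc12`, differs from compound 3 by bromo in place of chloro on an aromatic carbon. Among the measured compounds shown here, none of the measured steps exchanges one halogen for another, so they give no direction here; the expected step of a 1.1-fold lower number from compound 3 to compound 4 (0.04 log units; within the scatter) is within the scatter. Compound 4 is estimated at 30000 nM, from 12000 nM to 75000 nM.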

Compound 4, half-maximal inhibitory concentration: > 50000 nM
Compound 4 was reported as a limit; the forecaster's own chance of this, stated with the estimate: 35%; middle value at least 1.6-fold (0.22 log units) from the limit.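

In this assay, among these compounds, bromo in place of chloro on this aromatic carbon gives an at least 1.5-fold higher number from compound 3 to compound 4 (0.18 log units; that floor lies within the scatter), the first halogen-for-halogen exchange, and it reads only as a floor. Compound 4 is a limit of the assay and joins compound 1 and compound 2 there: the limit of > 50000 nM in this assay, at which 3 of the 4 values shown sit. The steps from compound 1 and from compound 2 to compound 4 cannot be read.

Open, from the compounds shown here alone, is whether an amine or a carboxylic acid in place of chloro at this same carbon would give a step beyond the scatter from compound 3.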